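The source may hold more compounds than are shown below. What is called first, only, known or untested is meant among the compounds shown, and "the series" means these compounds.

Compound 1 `COc1c(N2CC[C@@H](CN)C2)c(F)cc2c(=O)c(C(=O)O)cn(Cc3ccc(-c4ccccc4)cc3)c12` carries a 3-(aminomethyl)pyrrolidin-1-yl group and a methoxy group on its core; in an assay on isolated protein for inhibition of DNA topoisomerase 1 (Homo sapiens), with a stated time of 15 min (on this read-out higher numbers stand for weaker inhibition and lower numbers for stronger inhibition), compound 1 gives 26000 nM. Compound 2 `CNC[C@@H]1CCN(c2c(F)cc3c(=O)c(C(=O)O)cn(Cc4ccc(-c5ccccc5)cc4)c3c2OC)C1` differs from compound 1 by methyl in place of hydrogen on an amine nitrogen, and in this assay compound 2 gives 155000 nM, which is a 6.0-fold higher number from compound 1 to compound 2 (0.78 log units; beyond the scatter). Compound 3 `NC[C@@H]1CCN(c2cc3c(cc2F)c(=O)c(C(=O)O)cn3Cc2ccc(-c3ccccc3)cc2)C1` differs from compound 1 by hydrogen in place of methoxy on an aromatic carbon; in this assay compound 3 gives 15600 nM, a result a 1.7-fold lower number from compound 1 to compound 3 (0.22 log units; within the scatter), so compound 1 and compound 3 are not separated here. Compound 4 `CNC[C@@H]1CCN(c2cc3c(cc2F)c(=O)c(C(=O)O)cn3Cc2ccc(-c3ccccc3)cc2)C1` is not yet measured. It differs from compound 3 by methyl in place of hydrogen on an amine nitrogen, the same change as that from compound 1 to compound 2, made at a place described in the same words; the two cores differ by hydrogen in place of methoxy on an aromatic carbon. Among the measured compounds shown here, the step here is expected to be a 6.0-fold higher number from compound 3 to compound 4 (0.78 log units; beyond the scatter), taken to match a 6.0-fold higher number from compound 1 to compound 2 (0.78 log units; beyond the scatter) as the only precedent available. Compound 4 is therefore estimated at 94000 nM, expected to fall between 40000 nM and 220000 nM.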

Compound 4, half-maximal inhibitory concentration: 168000 nM
For compound 4 the middle estimate is 1.8-fold (0.25 log units) below the measured one, and the stated range covers the measured number.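

In this assay the change from aminomethyl to (methylamino)methyl also raises the number on the core without methoxy (an 11-fold higher number from compound 3 to compound 4 (1.03 log units; beyond the scatter)), and the two steps agree: the same change on two cores in this assay, a 6.0-fold higher number (0.78 log units; beyond the scatter) from compound 1 to compound 2 and an 11-fold higher number (1.03 log units; beyond the scatter) from compound 3 to compound 4, 1.8-fold (0.26 log units) apart, within the scatter of two such steps.
Hydrogen in place of methoxy leaves the two methylated compounds unseparated (a 1.1-fold higher number from compound 2 to compound 4 (0.03 log units; within the scatter)), as it did the two unmethylated ones: the same change on two cores in this assay, a 1.7-fold lower number (0.22 log units; within the scatter) from compound 1 to compound 3 and a 1.1-fold higher number (0.03 log units; within the scatter) from compound 2 to compound 4, 1.8-fold (0.26 log units) apart, within the scatter of two such steps.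
So the methyl step carries over between these two cores, but a single pair of cores shows neither how it behaves on any other core nor what lies behind it.

Going by these compounds, whether an ethyl group or a second methyl on the amine nitrogen brings a similar loss remains open. So does the effect of a longer chain carrying the amine.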